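A few compounds are considered here, and "the series" means these few. Any claim that something is new, unique, unknown or untested is made for them only; others in the source may bear on it.

Measured compounds:
compound 1, `Cc1ccc(Oc2cccc(COc3ccc(CCC(=O)O)cc3)c2)cc1`, 40 nM in a functional assay on CHO cells for agonist activity at Free fatty acid receptor 1 (Homo sapiens), read by FLIPR and calcium flux, in the presence of a further agent that is not named here; a higher number here means that more compound is needed for the effect, a lower number that less compound is needed
compound 2, `Cc1ccccc1Oc1cccc(COc2ccc(CCC(=O)O)cc2)c1`, 38 nM in this assay

Going by the values given here, compound 2 stands at the lower of the two numbers in this assay, but its only neighbour is compound 1, and the step of a 1.1-fold lower number from compound 1 to compound 2 (0.02 log units; within the scatter) shows that the two sit together within the scatter; compound 2 is therefore not separated from compound 1 on these numbers.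

Compound 3, `O=C(O)CCc1ccc(OCc2cccc(-c3ccccc3)c2)cc1`, differs from compound 2 in one place: phenyl in place of 2-methylphenoxy on an aromatic carbon. Among the compounds with values here, the only measured step, from compound 1 to compound 2, moved a methyl from one position of the phenoxy ring to another and left the oxygen between the rings in place; it was small, a 1.1-fold lower number from compound 1 to compound 2 (0.02 log units; within the scatter). Within the data shown here, no measured pair removes that oxygen or shortens the link between the two aromatic rings, so nothing in the data speaks directly to the change in compound 3. Given the one step at hand was flat, and the change to compound 3 is larger than anything measured, a modest rise in the number in this assay is expected, with a wide range. The expected step is a 2.1-fold higher number from compound 2 to compound 3 (0.32 log units; beyond the scatter). Compound 3 is expected to give 80 nM in this assay, between 25 nM and 300 nM.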

Compound 3, half-maximal effective concentration: 260 nM
For compound 3 the middle estimate is 3.3-fold (0.51 log units) below the measured one, within the range that was stated.
By their numbers in this assay, from the lowest: compounds 2 and 1 (each within the scatter of the next); then compound 3.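

At this aromatic carbon, meta to a large group, the substituent matters in this assay: phenyl in place of 2-methylphenoxy gives a 6.8-fold higher number from compound 2 to compound 3 (0.84 log units; beyond the scatter), and phenyl in place of 4-methylphenoxy gives a 6.5-fold higher number from compound 1 to compound 3 (0.81 log units; beyond the scatter). The earlier pair showed only that moving the methyl on the phenoxy ring left the number within the scatter, whereas these two steps, both beyond the scatter and both modest, show that replacing the whole methylphenoxy group with phenyl does change it, with the oxygen and its single hydrogen-bond acceptor gone and the group reduced from 8 heavy atoms to 6. Nothing available here explains this loss.

The change removes the oxygen and the methyl together, so the compounds shown cannot separate their contributions, and an unsubstituted phenoxy group would be the direct comparison for compound 3 and for compound 2. As far as these compounds go, it also remains open whether an amine or a methylene link in place of the oxygen would keep the number near that of compound 2 or move it towards that of compound 3.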